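The source may report more compounds than this note shows. Statements on the series, on what has been measured and on what is new or still open speak of the compounds shown alone.

Measured so far in a functional assay on cells (Endothelial cell, Bos taurus) for antiproliferative activity; on this read-out lower numbers stand for stronger inhibition and higher numbers for weaker inhibition
- compound 1 `COc1ccc(/C(F)=C(/F)c2cc(OC)c(OC)c(OC)c2)cc1N` gives 3600 nM
- compound 2 `COc1ccc(/C(F)=C(\F)c2cc(OC)c(OC)c(OC)c2)cc1[N+](=O)[O-]` gives 2300000 nM
- compound 3 `COc1ccc(/C(F)=C(/F)c2cc(OC)c(OC)c(OC)c2)cc1O` gives 4600 nM

Among these three, compound 3 stands level with compound 1 and far from compound 2. Its number is the one to start from here.

Compound 4 `COc1ccc(/C(F)=C(/F)c2cc(OC)c(OC)c(OC)c2)cc1[N+](=O)[O-]` keeps the shared core of compound 3 and the same arrangement at the double bond. Among the measured compounds shown here, the one change is nitro in place of hydroxy on an aromatic carbon, ortho to a methoxy group (nitro in place of hydroxy on an aromatic carbon).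

For the measured compounds named here, only one measured step touches this place directly. In it, hydroxy replaces amino, and the result is a 1.3-fold higher number from compound 1 to compound 3 (0.11 log units; within the scatter). So that exchange left the number unchanged within normal variation, but it says little about a nitro group, which is larger and has no hydrogen-bond donor. Nitro also appears in compound 2, but the double bond there has the opposite arrangement. That makes compound 2, at 2300000 nM, a loose warning and not a direct guide.

A modest rise in this assay is therefore expected, and the estimated step is a 2.6-fold higher number from compound 3 to compound 4 (0.42 log units; beyond the scatter). For compound 4 the expected value is 12000 nM, with an estimated range from 2500 nM to 80000 nM.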

Compound 4, half-maximal inhibitory concentration: 749000 nM
The estimate for compound 4 lay 62-fold (1.80 log units) below the measured number, outside the stated range (above it).
By their numbers in this assay, from the lowest: compounds 1 and 3 (each within the scatter of the next); then compound 4; then compound 2.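

In this assay, this position proves far less forgiving than the exchange of amino and hydroxy suggested: nitro in place of hydroxy gives a 160-fold higher number from compound 3 to compound 4 (2.21 log units; beyond the scatter), and nitro in place of amino gives a 210-fold higher number from compound 1 to compound 4 (2.32 log units; beyond the scatter). So the groups at this position are not interchangeable, and among the compounds with this arrangement at the double bond, the nitro compound stands well apart from the other two. Reversing the arrangement at the double bond gives a 3.1-fold lower number from compound 2 to compound 4 (0.49 log units; beyond the scatter), a much smaller step than either nitro exchange, and this step can be read as the effect of that arrangement alone: the fact that compounds 2 and 4 differ only in the configuration as drawn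

Nitro differs from hydroxy both in having more heavy atoms and in having no hydrogen-bond donor, and the compounds shown cannot separate these two differences; a methyl group or a nitrile at this position would help to pull them apart. Going by these compounds, it also remains open whether the amino and hydroxy compounds would respond to reversing the double bond as the nitro pair does.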